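Swapping a Chlorophenyl for a Pyridyl on a Triazole

The source may hold more compounds than are shown below. What is called first, only, known or untested is meant among the compounds shown, and "the series" means these compounds.

Of the compounds shown here, three sharing one core have been tested in a functional assay on A549 cells (Homo sapiens) for cytotoxicity, read by MTT assay, with a stated time of 4 days; a lower number here means a stronger inhibitor, a higher number a weaker inhibitor. Compound 1 `Cc1c(O)ccc2c1[C@H](Cn1cc(-c3ccc(Cl)cc3)nn1)[C@@]13CC(=O)[C@@](C)(CC[C@@H]21)C3` gives > 20000 nM, which is a limit of the assay rather than a number. Compound 2 `C=C1C(=O)[C@]23C[C@@]1(O)CC[C@H]2c1ccc(O)c(C)c1[C@@H]3Cn1cc(-c2ccccc2)nn1` gives 1160 nM. Compound 3 `C=C1C[C@]23C[C@@]1(O)CC[C@@H]2c1cccc(C)c1[C@@H]3Cn1cc(-c2ccc(Cl)cc2)nn1` gives > 20000 nM, again a limit. Compound 3 therefore stands at the limit of this assay, the point where two of the three values sit (the limit of > 20000 nM in this assay, at which 2 of the 3 values shown sit). Only compound 2 stands as an actual number.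

Compound 4 `C=C1C[C@]23C[C@@]1(O)CC[C@@H]2c1cccc(C)c1[C@@H]3Cn1cc(-c2ccccn2)nn1` differs from compound 3 in one place: pyridin-2-yl in place of 4-chlorophenyl on an aromatic carbon. Within the data shown here, no step between two measured compounds is available here, so the size of this change cannot be read off from the data. The step from compound 3 to compound 4 is expected to be a number no higher from compound 3 to compound 4 (the limit leaves the size open), that is, none beyond the scatter. This expectation rests on compound 3 sitting at the limit of > 20000 nM in this assay, at which 2 of the 3 values shown sit. Compound 4 is estimated at 20000 nM, within a range of 5000 nM to 60000 nM, and the assay may well report only a limit again.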

Compound 4, half-maximal inhibitory concentration: > 20000 nM
Compound 4: a limit, no number; the forecaster's own chance of this, stated with the estimate: 70%; the middle value sits exactly at the limit.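

In this assay compound 4 gives > 20000 nM, which is a limit of the assay and not a number. Among these compounds, compound 3 also sits at a limit, so no step between compound 3 and compound 4 can be read. From the compounds shown here alone, whether pyridin-2-yl or 4-chlorophenyl gives the stronger inhibitor remains open.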